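Moving fluorine around the sulfonyl-bound ring

The source may report more compounds than this note shows. Statements on the series, on what has been measured and on what is new or still open speak of the compounds shown alone.

Compound 1 `Cc1ccccc1C(=O)NCc1ccc(CNS(=O)(=O)c2ccc(Cl)cc2)cc1`, 1 nM
Compound 2 `Cc1ccccc1C(=O)NCc1ccc(CNS(=O)(=O)c2cccc(Cl)c2)cc1`, 100 nM
Compound 3 `Cc1ccccc1C(=O)NCc1ccc(CNS(=O)(=O)c2ccccc2F)cc1`, 1000 nM

All three compounds share one core and differ only in the ring attached to the sulfonyl sulfur. In an assay on MDA-MB-231 cells for displacement of a labelled ligand from C-X-C chemokine receptor type 4 (Homo sapiens), read by fluorescence and microscopy, with stated times of 10 min and 30 min (on this read-out higher numbers stand for an effect only at larger amounts of compound and lower numbers for an effect already at smaller amounts), compound 3 shows the highest number of the three: compound 2 sits at a 10-fold higher number from compound 2 to compound 3 (1.00 log units; beyond the scatter), and compound 1 at a 1000-fold higher number from compound 1 to compound 3 (3.00 log units; beyond the scatter), so compound 3 is the weakest of the measured set.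

Compound 4 `Cc1ccccc1C(=O)NCc1ccc(CNS(=O)(=O)c2cccc(F)c2)cc1` has not been measured. It differs from compound 3 in one place: 3-fluorophenyl in place of 2-fluorophenyl on a sulfonyl sulfur.

Among the compounds with values here, the step of a 10-fold higher number from compound 2 to compound 3 (1.00 log units; beyond the scatter) is the closest guide, since it also moves the halogen from the 2-position to the 3-position of the sulfonyl-bound ring, though with chlorine rather than fluorine; no measured pair compares fluorine with chlorine at the same position. The step of a 100-fold higher number from compound 1 to compound 2 (2.00 log units; beyond the scatter) shows that this ring is sensitive to where the halogen sits.

For compound 4 a lower number than compound 3 is therefore expected, a 3.3-fold lower number from compound 3 to compound 4 (0.52 log units; beyond the scatter), landing near compound 2. The estimate for compound 4 is 300 nM, within 60 nM to 2000 nM.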

Compound 4, effective concentration (reported as EC, without a stated level of effect): 100 nM
Compound 4: middle estimate off by 3.0-fold (0.48 log units), on the high side; low and high end bracket the measured number.
By their numbers in this assay, from the lowest: compound 1; then compounds 2 and 4 (each within the scatter of the next); then compound 3.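

Compounds 3 and 4 hold the same atoms, so their difference isolates the site of the fluorine on the ring, and moving it has a clear effect (a 10-fold lower number from compound 3 to compound 4 (1.00 log units; beyond the scatter)). Fluoro and chloro can now be compared at one position, and swapping them leaves the result unchanged (no change at the digits printed from compound 2 to compound 4 (within the scatter)), so among compounds 2, 3 and 4, where the halogen sits counts for more in this assay than which of the two halogens it is. Compound 4 also remains far from compound 1 (a 100-fold higher number from compound 1 to compound 4 (2.00 log units; beyond the scatter)), although that step changes both the halogen and its place.

No measured evidence here explains these differences. Still open, from the compounds shown here alone, is whether fluorine could match the chlorine of the 4-chlorophenyl ring in compound 1, and how a methoxy group or an amine would fare on this ring.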